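Bromo to methoxy on the aryl ring of compound 2

A few compounds are considered here, and "the series" means these few. Any claim that something is new, unique, unknown or untested is made for them only; others in the source may bear on it.

Three analogues of the shared core have been measured in an ADME assay on NIH3T3 cells (Mus musculus) for cytotoxicity, read by MTT assay, with a stated time of 24 h; a lower number here means a stronger inhibitor, a higher number a weaker inhibitor. Compound 1 `O=C(CSc1nnnn1-c1ccccc1)N/N=c1/scc(-c2ccc(Br)cc2)n1-c1ccccc1` gives 433 ug/mL. Compound 2 `Cn1cnnc1SCC(=O)N/N=c1/scc(-c2ccc(Br)cc2)n1-c1ccccc1` gives 58.3 ug/mL, and compound 3 `Cc1nnc(SCC(=O)N/N=c2/scc(-c3ccc(Br)cc3)n2-c2ccccc2)s1` gives 55 ug/mL. Compound 2 thus stands second highest of the three numbers: the steps of a 7.4-fold lower number from compound 1 to compound 2 (0.87 log units; beyond the scatter) and a 7.9-fold lower number from compound 1 to compound 3 (0.90 log units; beyond the scatter) lie beyond the scatter, whereas a 1.1-fold lower number from compound 2 to compound 3 (0.03 log units; within the scatter) lies within it. Compound 4 `COc1ccc(-c2cs/c(=N/NC(=O)CSc3nncn3C)n2-c2ccccc2)cc1` differs from compound 2 by methoxy in place of bromo on an aromatic carbon. Going by the values given here, no measured step touches that ring; all three measured compounds vary only the group on the sulfur, so nothing here shows how this assay responds to this exchange. The expected step is therefore a 1.0-fold higher number from compound 2 to compound 4 (0.01 log units; within the scatter), none beyond the scatter. Compound 4 is estimated at 60 ug/mL, with a range from 25 ug/mL to 150 ug/mL.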

Compound 4, half-maximal inhibitory concentration: 167 ug/mL
Compound 4: middle estimate off by 2.8-fold (0.44 log units), on the low side; the measured number lies above the stated range.
By their numbers in this assay, from the lowest: compounds 3 and 2 (each within the scatter of the next); then compound 4; then compound 1.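

The aryl ring is not a silent position in this assay: methoxy in place of bromo gives a 2.9-fold higher number from compound 2 to compound 4 (0.46 log units; beyond the scatter), so this number responds to a change on that ring as well as to the group on the sulfur. This is one exchange on one compound and does not set a trend for the ring. No measurement at hand accounts for the step. On these data alone, whether it holds with 5-methyl-1,3,4-thiadiazol-2-yl or 1-phenyl-1H-tetrazol-5-yl on the sulfur remains open. So does the response to an amine or a carboxylic acid at this aromatic carbon.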